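Urea series on OVCAR-4: trifluoromethyl exchanged for chloro

The source may report more compounds than this note shows. Statements on the series, on what has been measured and on what is new or still open speak of the compounds shown alone.

Compound 2 `O=C(Nc1cccc(-n2cc(-c3ccncc3)c(-c3cc(O)cc(Cl)c3)n2)c1)Nc1ccc(Cl)c(C(F)(F)F)c1` holds the lowest of the two numbers in hand: in a functional assay on OVCAR-4 cells (Homo sapiens) for inhibition, read by sulforhodamine B assay, with a stated time of 48 h, tested at 10 uM (on this read-out higher numbers stand for a weaker effect at the one concentration tested and lower numbers for a stronger effect), compound 2 gives 31.6%. Compound 1 `COc1cc(Cl)cc(-c2nn(-c3cccc(NC(=O)c4ccc(Cl)c(Cl)c4)c3)cc2-c2ccncc2)c1` gives 58.6% in this assay, a number higher than that of compound 2 by a gap beyond the scatter. Compound 3 `O=C(Nc1cccc(-n2cc(-c3ccncc3)c(-c3cc(O)cc(Cl)c3)n2)c1)Nc1ccc(Cl)c(Cl)c1` is not yet measured; it differs from compound 2 by chloro in place of trifluoromethyl on an aromatic carbon. Among the compounds with values here, no measured step of this kind exists, so the expected step from compound 2 to compound 3 is a number 6.4 percentage points higher from compound 2 to compound 3 (within the scatter), amounting to none beyond the scatter. Compound 3 is estimated at 38%, with a range from 22% to 58%.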

Compound 3, a percentage reported as activity, at one concentration (the size of the read-out at that concentration, not a potency): 10.7%
For compound 3 the middle estimate is 27.3 percentage points above the measured one; measured number below the stated range.
By their numbers in this assay, from the lowest: compound 3; then compound 2; then compound 1.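

In this assay the change of 4-chloro-3-(trifluoromethyl)phenyl to 3,4-dichlorophenyl gives a number 20.9 percentage points lower from compound 2 to compound 3 (beyond the scatter) with the rest of the structure held constant. Within the data shown here, this is the first reading on this position: the read-out responds to the group placed here, and chloro, with one heavy atom against four, gives the stronger effect at the one concentration tested. Nothing in hand bears on the reason for this.

Going by these compounds, what methyl, bromo or nitrile would give on this aromatic carbon remains open. So does whether the exchange carries over to other parts of the series.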